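The source may hold more compounds than are shown below. What is called first, only, known or untested is meant among the compounds shown, and "the series" means these compounds.

In a physicochemical assay for solubility, in phosphate buffer, at pH 7.4 (a lower number here means a less soluble compound, a higher number a more soluble compound), compound 1 `OCCC1CCN(c2nccnc2OC2CN(c3ccc4ccccc4n3)C2)CC1` gives 84000 nM and compound 2 `OCC1CCN(c2nccnc2OC2CN(c3ccc4ccccc4n3)C2)C1` gives 167000 nM. Within the data shown here, these are the only two numbers available, and they lie within the usual scatter of each other, so compound 2 cannot be ranked apart from compound 1.

The next structure, compound 3 `COCC1CCN(c2nccnc2OC2CN(c3ccc4ccccc4n3)C2)CC1`, keeps the shared core and changes one group: 4-(methoxymethyl)piperidin-1-yl in place of 3-(hydroxymethyl)pyrrolidin-1-yl on an aromatic carbon. Among the measured compounds shown here, only one measured step bears on this change: a 2.0-fold higher number from compound 1 to compound 2 (0.30 log units; within the scatter). It placed 3-(hydroxymethyl)pyrrolidin-1-yl where 4-(2-hydroxyethyl)piperidin-1-yl stood, and it stayed within the scatter. Exchanging these two rings has therefore shown no clear shift so far. For the measured compounds named here, no measured step shows what a methoxymethyl group does in place of a hydroxymethyl group, so that part of the change is untested and the expectation is loose.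

The closest measured relative of compound 3 with a six-membered ring is compound 1, at 84000 nM. A moderate fall in this assay is expected, with the estimated change being a 3.3-fold lower number from compound 2 to compound 3 (0.52 log units; beyond the scatter). For compound 3 the expected value is 50000 nM, with an estimated range from 15000 nM to 130000 nM.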

Compound 3, solubility: 53000 nM
Estimate against measurement, compound 3: 1.1-fold (0.03 log units) below; measured number inside the range.
By their numbers in this assay, from the lowest: compounds 3, 1 and 2 (each within the scatter of the next, the first and the last beyond it).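

In this assay, among these compounds, the group on the aromatic carbon next to the ring nitrogen now gives a first step beyond the scatter, a 3.2-fold lower number from compound 2 to compound 3 (0.50 log units; beyond the scatter) when 4-(methoxymethyl)piperidin-1-yl replaces 3-(hydroxymethyl)pyrrolidin-1-yl. The step that keeps a six-membered ring is a 1.6-fold lower number from compound 1 to compound 3 (0.20 log units; within the scatter) and compound 1 therefore sits within the scatter of both other compounds, so the clear gap appears only when the two ends of the series are compared, and that comparison changes the ring size and the chain together, which leaves the gap not assignable to either change alone. Nothing available here gives a measured reason for this step.

The compounds shown leave open how 3-(methoxymethyl)pyrrolidin-1-yl would read, since that group would pair the five-membered ring with the methoxymethyl chain and so separate the two changes. Also open, from the compounds shown here alone, is whether an amine or a carboxylic acid on the chain, in place of the hydroxyl or methoxy oxygen, would move the number beyond the scatter of compound 1.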